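This account rests on a few compounds, and the source may have more. Where it says the series, first, only, none or still open, it means among the compounds named here.

In a functional assay on CHO-K1 cells for agonist activity at Glucose-dependent insulinotropic receptor (Homo sapiens), read by a luciferase reporter, with a stated time of 5 h (a higher number here means that more compound is needed for the effect, a lower number that less compound is needed), compound 2 `CCCS(=O)(=O)N1CCN(c2ccc(OCC3CCN(C(=O)OC(C)C)CC3)cn2)CC1` gives 300 nM, and compound 3 `COCCS(=O)(=O)N1CCN(c2ccc(OCC3CCN(C(=O)OC(C)C)CC3)cn2)CC1` gives 300 nM; the step of no change at the digits printed from compound 2 to compound 3 (within the scatter) shows the two sitting level. Compound 1 `CC(C)NC(=O)CN1CCN(c2ccc(OCC3CCN(C(=O)OC(C)C)CC3)cn2)CC1` reaches only a limit in this assay, > 10000 nM. The steps of an at least 33-fold lower number from compound 1 to compound 2 (1.52 log units; beyond the scatter) and an at least 33-fold lower number from compound 1 to compound 3 (1.52 log units; beyond the scatter) are large, yet both rest on the limit of > 10000 nM in this assay, at which 1 of the 3 values shown sits, and both exchange the whole group on the ring nitrogen rather than the substituent on the sulfonyl sulfur.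

Compound 4 `CC(C)OC(=O)N1CCC(COc2ccc(N3CCN(S(=O)(=O)c4cccnc4)CC3)nc2)CC1` differs from compound 2 in one place: pyridin-3-yl in place of propyl on a sulfonyl sulfur. For the measured compounds named here, the only measured step that alters a substituent on the sulfonyl sulfur, no change at the digits printed from compound 2 to compound 3 (within the scatter), stayed within the scatter, though it swapped one chain for another, and no measured compound carries an aromatic ring at that position. The expectation in this assay is therefore a step of no more than modest size, with the direction left open, no change at the digits printed from compound 2 to compound 4 (within the scatter). Compound 4 is estimated at 300 nM, between 70 nM and 1500 nM.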

Compound 4, half-maximal effective concentration: 2000 nM
Compound 4: middle estimate off by 6.7-fold (0.82 log units), on the low side; measured number above the stated range.
By their numbers in this assay, from the lowest: compounds 2 and 3 (each within the scatter of the next); then compound 4. At a limit, above all of these: compound 1.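

In this assay the substituent on the sulfonyl sulfur now matters: propyl and 2-methoxyethyl had sat level, while pyridin-3-yl gives a 6.7-fold higher number from compound 2 to compound 4 (0.82 log units; beyond the scatter) and a 6.7-fold higher number from compound 3 to compound 4 (0.82 log units; beyond the scatter). These are the only steps at this position that lie beyond the scatter, and they come with the one aromatic ring shown there, so a ring and its nitrogen enter together and their shares cannot be told apart. Even so, the sulfonyl compound with pyridin-3-yl keeps an edge over the compound with the (isopropylcarbamoyl)methyl group, an at least 5.0-fold lower number from compound 1 to compound 4 (0.69 log units; beyond the scatter), but that step rests on a limit of compound 1: the limit of > 10000 nM in this assay, at which 1 of the 4 values shown sits.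

A phenyl group on the sulfonyl sulfur would separate the effect of the aromatic ring from that of its nitrogen. From the compounds shown here alone, how far chains stay level at this position also remains open, for example with methyl or a longer chain such as hexyl.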